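A few compounds are considered here, and "the series" means these few. Any claim that something is new, unique, unknown or untested is made for them only; others in the source may bear on it.

- Compound 1 (`COc1ccc(C(=O)c2sc(N3CCCC3)nc2N)cc1OC`) gives 31000 nM 
- Compound 2 (`COc1ccc(C(=O)c2sc(N3CCCC3)nc2N)cc1`) gives > 200000 nM as a limit of the assay

Within the data shown here, in a functional assay on MOLT-4 cells (Homo sapiens) for antiproliferative activity, read by cell counting, with a stated time of 2 days (on this read-out lower numbers stand for stronger inhibition and higher numbers for weaker inhibition), compound 1 gives 31000 nM as the only exact number so far. Compound 2 gives only a limit, > 200000 nM, and not an exact number.

Compound 3 (`COc1cccc(C(=O)c2sc(N3CCCC3)nc2N)c1`) is still unmeasured. It differs from compound 1 by hydrogen in place of methoxy on an aromatic carbon, with hydrogen in place of methoxy on an aromatic carbon, para to a large group. One measured step makes the same kind of swap at the other methoxy group: an at least 6.4-fold higher number from compound 1 to compound 2 (0.80 log units; beyond the scatter). A rise beyond the scatter is therefore expected in this assay, though one step cannot fix its size. The expected change is a 2.9-fold higher number from compound 1 to compound 3 (0.46 log units; beyond the scatter). Compound 3 is estimated at 90000 nM, with an expected range from 30000 nM to 200000 nM.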

Compound 3, half-maximal inhibitory concentration: > 200000 nM
Compound 3: only a limit was reported (the forecaster's own chance of this, stated with the estimate: 40%); at least 2.2-fold (0.34 log units) between middle value and limit.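

Removing this methoxy group, the one para to a large group, also costs activity, with an at least 6.4-fold higher number from compound 1 to compound 3 (0.80 log units; beyond the scatter) in this assay. Compound 3 gives only a limit, not an exact number. Since the other methoxy swap also ends at a limit, neither methoxy group can be lost here without activity falling beyond the scatter.

From the compounds shown here alone, whether a hydroxyl, an ethoxy or a fluorine could replace methoxy at this position stays open. Going by these compounds, compounds 2 and 3 cannot be ranked against each other, and the full size of each step stays unknown, because both end at the same limit: the limit of > 200000 nM in this assay, at which 2 of the 3 values shown sit.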